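Moving a methyl from the chain onto the nitrogen

The source may report more compounds than this note shows. Statements on the series, on what has been measured and on what is new or still open speak of the compounds shown alone.

The series shares one core, seen in compound 1 `CCCCNc1nc2cc(-c3ccc(C)cc3)sc2c(=O)[nH]1`, compound 2 `CCCCCNc1nc2cc(-c3ccc(C)cc3)sc2c(=O)[nH]1` and compound 3 `CCCCCCC(C)Nc1nc2cc(-c3ccc(C)cc3)sc2c(=O)[nH]1`. In an ADME assay on HepG2 cells (Homo sapiens) for cytotoxicity, read by MTT assay, with a stated time of 72 h (a higher number here means that more compound is tolerated, a lower number that less compound is tolerated), compound 1 gives 6000 nM, compound 2 gives 4200 nM and compound 3 gives 19400 nM. Compound 2 holds the lowest of the three numbers, with compound 1 nearest and compound 3 furthest. The step of a 1.4-fold lower number from compound 1 to compound 2 (0.15 log units; within the scatter) lies within the scatter, whereas a 3.2-fold higher number from compound 1 to compound 3 (0.51 log units; beyond the scatter) and a 4.6-fold higher number from compound 2 to compound 3 (0.66 log units; beyond the scatter) are both beyond it and modest in size.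

Compound 4 `CCCCN(C)c1nc2cc(-c3ccc(C)cc3)sc2c(=O)[nH]1` differs from compound 2 by butyl(methyl)amino in place of pentylamino on an aromatic carbon. Among the measured compounds shown here, no measured step moves a methyl from the chain onto the nitrogen or removes the hydrogen-bond donor, so none bears on this change directly. The nearest comparison is compound 1 to compound 2, where methyl in place of hydrogen on a saturated chain carbon gave a 1.4-fold lower number from compound 1 to compound 2 (0.15 log units; within the scatter), and the branched compound 3 moved the number modestly higher. The number for compound 4 in this assay is therefore expected to stay within the scatter of compound 2 or to sit a little higher, estimated at 6000 nM with a range of 2500 nM to 15000 nM, an expected step of a 1.4-fold higher number from compound 2 to compound 4 (0.15 log units; within the scatter).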

Compound 4, half-maximal cytotoxic concentration: 3000 nM
Estimate against measurement, compound 4: 2.0-fold (0.30 log units) above, within the range that was stated.
By their numbers in this assay, from the lowest: compounds 4, 2 and 1 (each within the scatter of the next); then compound 3.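

In this assay, the swap of pentylamino for butyl(methyl)amino gives a 1.4-fold lower number from compound 2 to compound 4 (0.15 log units; within the scatter), and methyl in place of hydrogen on the nitrogen gives a 2.0-fold lower number from compound 1 to compound 4 (0.30 log units; within the scatter), both within the scatter. At this position, on the aromatic carbon between two ring nitrogen atoms, going from 1 hydrogen-bond donor in the group to 0 therefore leaves the number indistinguishable from those of the two straight-chain secondary amines, so this donor is not required to hold the reading in that range. No measurement available here explains this outcome.

The compounds shown leave open whether a second nitrogen substituent larger than methyl, such as in a dibutylamino group, would keep the number in this range. They also leave open how a chain ending in a carboxylic acid would read at this position.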